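Removing the methoxy from compound 2

This account rests on a few compounds, and the source may have more. Where it says the series, first, only, none or still open, it means among the compounds named here.

Measured values (a functional assay on a cell-free system (plasma, Oryctolagus cuniculus) for inhibition, with stated times of 5 min, 1 min and 6 min; a higher number here means a weaker inhibitor, a lower number a stronger inhibitor)
- compound 1 `CCOC(=O)c1c(C)nc(-c2cccc(C#N)c2)n1O` gives 17600 nM
- compound 2 `CCOC(=O)c1c(C)nc(-c2cccc(C#N)c2)n1OC` gives 9130 nM
- compound 3 `CCOC(=O)c1c(C)nc(-c2ccccc2)n1OC` gives > 30000 nM as a limit

Only compound 1 and compound 2 carry actual numbers, and these two lie within the scatter of each other. Among the compounds with values here, the third value is a limit, and compound 2 therefore stands level with the only other number.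

The next step leads to compound 4 `CCOC(=O)c1[nH]c(-c2cccc(C#N)c2)nc1C`, in which hydrogen takes the place of methoxy on an aromatic nitrogen (hydrogen in place of methoxy on an aromatic nitrogen). Within the data shown here, two measured steps bear on this change. Placing methyl on the oxygen gave a 1.9-fold lower number from compound 1 to compound 2 (0.29 log units; within the scatter), so the group on that oxygen has shown no effect beyond the scatter so far. Removing the cyano gave an at least 3.2-fold higher number from compound 2 to compound 3 (0.51 log units; beyond the scatter), but compound 4 keeps the cyano, so no loss of that kind is expected. Among the measured compounds shown here, no measured step removes the oxygen itself, so the range has to stay wide.

In this assay the expected result is a 1.6-fold higher number from compound 2 to compound 4 (0.22 log units; within the scatter), leaning towards a higher number without clearly leaving the scatter. For compound 4 the estimate is 15000 nM (expected range 5000 nM to 40000 nM).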

Compound 4, half-maximal inhibitory concentration: > 30000 nM
Compound 4: a limit, no number; the forecaster's own chance of this, stated with the estimate: 30%; middle value at least 2.0-fold (0.30 log units) from the limit.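

In this assay compound 4 gives > 30000 nM, a limit and not a number. Within the data shown here, replacing the methoxy on the aromatic nitrogen with hydrogen gives an at least 3.2-fold higher number from compound 2 to compound 4 (0.51 log units; beyond the scatter), the first change at this position that reaches beyond the scatter, whereas the methyl on the oxygen in the step between compound 1 and compound 2 did not; compound 4 also keeps the nitrile, so that group alone does not secure a measurable number. The step from the hydroxy compound is less clear, with an at least 1.7-fold higher number from compound 1 to compound 4 (0.23 log units; that floor lies within the scatter), so a loss at this position is shown only against the methoxy compound, and the full size of both steps cannot be read: the limit of > 30000 nM in this assay, at which 2 of the 4 values shown sit.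

From the compounds shown here alone, whether a longer chain on the oxygen, such as ethoxy or benzyloxy, or a methyl placed directly on the aromatic nitrogen would give a lower number remains open. The compounds shown also leave open what the ethoxycarbonyl group contributes, for example whether a carboxylic acid or a primary amide in its place would retain a measurable number.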